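The source may hold more compounds than are shown below. What is called first, only, known or untested is meant among the compounds shown, and "the series" means these compounds.

Compound 1 `CC[C@H]1CN(c2ncc(-c3nnc[nH]3)cc2Cl)CCN1C1CCN(Cc2ccc(Cl)cc2F)CC1` gives 6.8 nM in an assay on isolated protein for binding affinity to C-X-C chemokine receptor type 3 (Homo sapiens); on this read-out higher numbers stand for weaker inhibition and lower numbers for stronger inhibition. Compound 2 `CC[C@H]1CN(c2nc(N)c(-c3nnc(C)o3)nc2Cl)CCN1C1CCN(Cc2ccc(Cl)cc2)CC1` gives 0.4 nM in this assay.

Of the two measured compounds, compound 2 holds the lower number, and the gap to compound 1 lies beyond the scatter. Compound 3 `CC[C@H]1CN(c2nc(N)c(-c3nnc(C)o3)nc2Cl)CCN1C1CCN(C(=O)c2ccc(Cl)cc2)CC1` is the unmeasured one; relative to compound 2 it carries (4-chlorophenyl)carbonyl in place of 4-chlorobenzyl on an amine nitrogen in a ring. Among the compounds with values here, no pair of measured compounds differing in one place exists to guide the size of this change. The expected step is a 100-fold higher number from compound 2 to compound 3 (2.00 log units; beyond the scatter), toward a higher number and beyond the scatter. Compound 3 is estimated at 40 nM, with a range from 5 nM to 400 nM.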

Compound 3, half-maximal inhibitory concentration: 4.2 nM
For compound 3 the middle estimate is 9.5-fold (0.98 log units) above the measured one, outside the stated range (below it).
By their numbers in this assay, from the lowest: compound 2; then compounds 3 and 1 (each within the scatter of the next).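

On the amine nitrogen in the six-membered ring, (4-chlorophenyl)carbonyl in place of 4-chlorobenzyl gives an 11-fold higher number from compound 2 to compound 3 (1.02 log units; beyond the scatter) in this assay. Within the data shown here, this is the first size read for any change at this position, and it is a large loss, yet inhibition does not vanish: compound 3 still gives 4.2 nM. Nothing measured here accounts for the step. From the compounds shown here alone, whether a sulfonyl group in that place would stand nearer to compound 2 or to compound 3 remains open, as does whether the same step would hold on the core of compound 1.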